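Fluoro in Place of Hydrogen: An Untested Step

The compounds below may be only part of what the source reports. "The series", "measured", "known", "first", "only" and "open" are said of these compounds alone.

Compound 1 `CNc1nc(NCc2ccc(NC(C)=O)cc2)cc(-c2ccccn2)n1`: 0.55 nM
Compound 2 `CNc1nc(NCc2ccc(NS(C)(=O)=O)cc2)cc(-c2ccccn2)n1`: 0.18 nM

Of the compounds shown here, two have been measured in a functional assay on HEK293 cells for agonist activity at G-protein coupled receptor 39 (Homo sapiens), read by cAMP accumulation; a lower number here means that less compound is needed, a higher number that more compound is needed for the effect. Compound 1 gives 0.55 nM, and compound 2 gives 0.18 nM. Among the compounds with values here, of these two numbers, compound 1 holds the higher one: the change a 3.1-fold lower number from compound 1 to compound 2 (0.49 log units; beyond the scatter) is the only step known so far, and it concerns the group on the nitrogen attached to the aromatic ring, not the ring itself.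

Compound 3 `CNc1nc(NCc2ccc(NC(C)=O)cc2F)cc(-c2ccccn2)n1` differs from compound 1 in another way: fluoro in place of hydrogen on an aromatic carbon, on an aromatic carbon of a six-membered aromatic ring of carbon only, ortho to a large group and meta to the acetamido group. Within the data shown here, no measured step touches a hydrogen on that ring, so nothing in the two known values speaks directly to this change. The acetamido group of compound 1 is kept unchanged in compound 3. Absent any bearing step, the expectation in this assay is for no step beyond the scatter, which is to say a step of no change at the digits printed from compound 1 to compound 3 (within the scatter). For compound 3 the estimated value is therefore 0.55 nM, within a range from 0.15 nM to 2 nM.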

Compound 3, half-maximal effective concentration: 0.35 nM
Compound 3: the middle estimate sits 1.6-fold (0.20 log units) above what was measured; the measured number falls inside the stated range.
By their numbers in this assay, from the lowest: compounds 2, 3 and 1 (each within the scatter of the next, the first and the last beyond it).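

In this assay, fluoro in place of hydrogen on this aromatic carbon, ortho to a large group and meta to an acetamido group, gives a 1.6-fold lower number from compound 1 to compound 3 (0.20 log units; within the scatter). Within the data shown here, this is the first reading of a change on the ring itself, since the earlier step concerned only the group on the nitrogen, and it shows that this ring carbon can carry a fluoro with no step beyond the usual scatter of repeated measurements. The data shown offer no independent measurement that would explain why the number holds at this position.

Fluoro adds only one heavy atom, so the compounds shown leave open whether a chloro, a methyl or a methoxy group on the same carbon would also stay within the scatter of compound 1, or whether a larger group would produce a real step. They also leave open whether fluoro on this carbon would give a similar result when the methylsulfonyl group of compound 2 stands in place of the acetyl group, and whether the remaining hydrogens on this ring would tolerate the same change.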